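The source may report more compounds than this note shows. Statements on the series, on what has been measured and on what is new or still open speak of the compounds shown alone.

Compound 1, `COc1cc(-c2nnc(SCC(=O)c3ccccc3)n2N)cc(OC)c1OC`, gives 7800 nM in a functional assay on HepG2 cells (Homo sapiens) for antiproliferative activity, read by MTT assay, with a stated time of 48 h; a lower number here means a stronger inhibitor, a higher number a weaker inhibitor.
Compound 2, `COc1cc(-c2nnc(SCC(=O)c3ccc(F)cc3)n2N)cc(OC)c1OC`, gives 90400 nM.
Compound 3, `COc1cc(-c2nnc(SCC(=O)c3ccccc3F)n2N)cc(OC)c1OC`, gives 22600 nM.

In this assay compound 3 stands second highest of the three numbers, with compound 1 nearest to it and compound 2 furthest. The step of a 2.9-fold higher number from compound 1 to compound 3 (0.46 log units; beyond the scatter) and the step of a 4.0-fold lower number from compound 2 to compound 3 (0.60 log units; beyond the scatter) place it between the other two. Compound 4, `COc1cc(-c2nnc(SCC(=O)Nc3ccccc3C)n2N)cc(OC)c1OC`, differs from compound 3 in one place: (2-methylphenyl)amino in place of 2-fluorophenyl on a carbonyl carbon. Within the data shown here, none of the measured steps makes a change of this kind; all three concern fluorine on the ring attached to the carbonyl, so no measured step bears directly on it. What they do show is that changes at this part of the core move the number, modestly in a 4.0-fold lower number from compound 2 to compound 3 (0.60 log units; beyond the scatter) and largely in a 12-fold higher number from compound 1 to compound 2 (1.06 log units; beyond the scatter). Among the measured compounds shown here, with no direct precedent, the number for compound 4 is expected near that of compound 3, and the step of a 1.1-fold lower number from compound 3 to compound 4 (0.05 log units; within the scatter) is estimated as small. Compound 4 is therefore estimated at 20000 nM, within the wide range 4000 nM to 90000 nM.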

Compound 4, half-maximal inhibitory concentration: > 100000 nM
Compound 4: a limit, no number; the forecaster's own chance of this, stated with the estimate: 5%; middle value at least 5.0-fold (0.69 log units) away from the limit.
By their numbers in this assay, from the lowest: compound 1; then compound 3; then compound 2. At a limit, above all of these: compound 4.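

The (2-methylphenyl)amino group is the first change shown that puts something other than an aromatic ring carbon on this carbonyl carbon, and in this assay it gives an at least 4.4-fold higher number from compound 3 to compound 4 (0.64 log units; beyond the scatter), a shift that the fluorine moves alone did not reveal. Measured against the phenyl of compound 1, the change is larger, an at least 12-fold higher number from compound 1 to compound 4 (1.10 log units; beyond the scatter), whereas an at least 1.1-fold higher number from compound 2 to compound 4 (0.04 log units; that floor lies within the scatter) has a floor within the scatter, so compound 4 cannot be set apart from compound 2. All three steps rest on a limit rather than a number: the limit of > 100000 nM in this assay, at which 1 of the 4 values shown sits.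

As far as these compounds go, it stays open whether the step follows the amino link or the methyl on the ring, which a phenylamino or (2-fluorophenyl)amino group on the same carbonyl carbon would separate. From the compounds shown here alone, how a cyclohexylamino group or a carboxylic acid would read there is also open.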